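The compounds below may be only part of what the source reports. "The series", "measured", "known", "first", "only" and "open" are said of these compounds alone.

In a functional assay on HepG2 cells (Homo sapiens) for inhibition, read by MTT assay, with a stated time of 48 h (on this read-out higher numbers stand for weaker inhibition and lower numbers for stronger inhibition), compound 3 `COc1ccc(N(C)c2nc(C)nc3ccccc23)cc1C(=O)OCCC[Se]C#N` gives 340 nM and stands lowest of the three, against compound 1 `COc1ccc(N(C)c2nc(C)nc3ccccc23)cc1C(=O)OCC[Se]C#N` with 890 nM and compound 2 `COc1ccc(N(C)c2nc(C)nc3ccccc23)cc1OCCCCCC[Se]C#N` with 4890 nM on the same read-out. Among the compounds with values here, compound 4 `COc1ccc(N(C)c2nc(C)nc3ccccc23)cc1C(=O)NCC[Se]C#N` differs from compound 3 by a group of 6 heavy atoms (3 carbon, 2 nitrogen, 1 selenium; no ring) in place of a group of 7 heavy atoms (4 carbon, 1 nitrogen, 1 oxygen, 1 selenium; no ring), on a carbonyl carbon and has no measurement yet. Within the data shown here, no measured step makes this exact exchange. The closest is a 2.6-fold lower number from compound 1 to compound 3 (0.42 log units; beyond the scatter) which touched only the selenium-bearing chain and was modest, while a 14-fold lower number from compound 2 to compound 3 (1.16 log units; beyond the scatter) was large but changed more of the molecule. A modest rise is therefore expected in this assay and the estimated step is a 2.6-fold higher number from compound 3 to compound 4 (0.42 log units; beyond the scatter) in this series. The estimate for compound 4 is 900 nM with 300 nM to 3000 nM as the expected range.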

Compound 4, half-maximal inhibitory concentration: 179 nM
Beside the measured number, compound 4's estimate is 5.0-fold (0.70 log units) above it, and the stated range ends above it.
By their numbers in this assay, from the lowest: compounds 4 and 3 (each within the scatter of the next); then compound 1; then compound 2.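

In this assay, within the data shown here, the exchange on the carbonyl carbon with the selenium-bearing chain length unchanged, a 5.0-fold lower number from compound 1 to compound 4 (0.70 log units; beyond the scatter), shows that an amide here beats the ester, which no earlier compound could show. With a 1.9-fold lower number from compound 3 to compound 4 (0.28 log units; within the scatter) lying within the scatter, the amide on the shorter chain reads the same as the ester on the longer chain. The widest gap in the set is now a 27-fold lower number from compound 2 to compound 4 (1.44 log units; beyond the scatter), though that step changes the whole group on the aromatic carbon.

Still open, from the compounds shown here alone, is whether a longer chain on the amide nitrogen would lower the number further, and whether a methyl group in place of the amide hydrogen would keep the result. No evidence is available to explain this result.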